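The source may report more compounds than this note shows. Statements on the series, on what has been measured and on what is new or still open speak of the compounds shown alone.

Compound 1, whose structure is `Fc1ccc(CNCc2cccc(F)c2F)cc1`, was tested in a functional assay on 3T3-L1 cells (Mus musculus) for inhibition, with a stated time of 20 min, tested at 20 uM (a higher number here means more inhibition at the concentration tested (going by the name of the read-out), a lower number less inhibition), and gives -53.4%. Among the two compounds measured so far this is the lowest number; the only other one is compound 2, with the structure `O=C(N(Cc1ccc(F)cc1)Cc1cccc(F)c1F)C(F)(F)F`, which in this assay gives -39.8%. Within the data shown here, the single measured step, a number 13.6 percentage points higher from compound 1 to compound 2 (beyond the scatter), comes from putting a (trifluoromethyl)carbonyl in place of hydrogen on an amine nitrogen.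

Compound 3, with the structure `Fc1cccc(CNCc2ccccc2)c1F`, has not yet been measured. It differs from compound 1 at one spot: hydrogen in place of fluoro on an aromatic carbon. Among the measured compounds shown here, the one step already known concerns the amine nitrogen, a different part of the molecule, so no measured step bears directly on removing a fluoro from the aromatic ring. With nothing in hand to say the ring fluorine matters, the expectation is a step of no more than the usual scatter, in either direction. The expected step is therefore a number 5.4 percentage points higher from compound 1 to compound 3 (within the scatter), and compound 3 is estimated to give -48% in this assay, with a range from -75% to -20%.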

Compound 3, a percentage reported as inhibition, at one concentration (the size of the read-out at that concentration, not a potency): -38.5%
Beside the measured number, compound 3's estimate is 9.5 percentage points below it; the range from low to high includes it.
By their numbers in this assay, from the lowest: compound 1; then compounds 2 and 3 (each within the scatter of the next).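

In this assay, hydrogen in place of fluoro on an aromatic carbon, para to a large group, gives a number 14.9 percentage points higher from compound 1 to compound 3 (beyond the scatter), a modest step. Among these compounds, until now, the only measured change was at the amine nitrogen, so this is the first sign that a single atom on an aromatic ring can also shift this read-out, and by a step beyond the scatter. Compound 3 still gives -38.5%, so the change makes the number higher without bringing it up to zero, and nothing available explains this shift.

The compounds shown leave open whether the effect depends on removing the fluoro itself or whether other groups on that aromatic carbon, such as a chloro, a methoxy or an amine, would give a similar number. Among the compounds shown here, they also leave open whether the step would be the same size with a (trifluoromethyl)carbonyl on the amine nitrogen, since the fluoro-to-hydrogen change has so far been seen only in compounds that keep the hydrogen there.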